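The source may report more compounds than this note shows. Statements on the series, on what has been measured and on what is new or still open speak of the compounds shown alone.

Measured so far:
compound 1, `C#CCOC(=O)C1=C(N)Oc2ccc(-c3cc(OC)cc(OC)c3)cc2C1CC(=O)CCC`: 6900 nM
compound 2, `CCOC(=O)CC1C(C(=O)OCC)=C(N)Oc2ccc(-c3cc(OC)cc(OC)c3)cc21`: 5400 nM
compound 3, `C#CCOC(=O)CC1C(C(=O)OCC#C)=C(N)Oc2ccc(-c3cccc(N)c3)cc21`: 1730 nM

All three compounds were tested in a functional assay on HL-60 cells (Homo sapiens) for inhibition, with a stated time of 48 h; on this read-out higher numbers stand for weaker inhibition and lower numbers for stronger inhibition. Compound 1 gives the highest number of the three. Compound 2 gives a lower number, but the gap to compound 1 lies within the scatter, so the two cannot be told apart. Compound 3 gives the lowest number, and its gap to compound 1 lies beyond the scatter; compound 3 differs from compound 1 in more than one place, so that gap cannot be tied to any single change.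

The next compound is compound 4, `C#CCOC(=O)C1=C(N)Oc2ccc(-c3cc(OC)cc(OC)c3)cc2C1CC(=O)c1ccccc1`. It differs from compound 1 in one place: phenyl in place of propyl on a carbonyl carbon. Among the measured compounds shown here, no pair among the measured compounds differs only in this way, so the data hold no step of this kind to lean on. A small step, if any, is therefore expected in this assay, with no clear direction beyond the scatter. For compound 4 the estimate in this assay is 5000 nM, with a range from 1500 nM to 16000 nM. The expected step is a 1.4-fold lower number from compound 1 to compound 4 (0.14 log units; within the scatter), judged to stay within the scatter.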

Compound 4, half-maximal inhibitory concentration: 7300 nM
Compound 4: the middle estimate sits 1.5-fold (0.16 log units) below what was measured; the measured number falls inside the stated range.
By their numbers in this assay, from the lowest: compound 3; then compounds 2, 1 and 4 (each within the scatter of the next).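

In this assay, among the compounds shown here, phenyl in place of propyl on a carbonyl carbon gives a 1.1-fold higher number from compound 1 to compound 4 (0.02 log units; within the scatter), the first comparison in this set in which only one place differs, and the two compounds cannot be told apart. For this pair, the read-out therefore does not separate a propyl chain of 3 heavy atoms from a phenyl group of 6 heavy atoms, which brings in a six-membered aromatic ring at this position. No measurement shown here bears on why the two groups read alike.

What the compounds shown leave open is whether an amine, a carboxylic acid, a longer chain or a phenyl ring carrying methoxy groups on this carbonyl carbon would give a number beyond the scatter from compound 1. This single pair also leaves open whether phenyl and propyl would still read alike in this assay if another part of the core of compound 1 carried a different group.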